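The compounds below may be only part of what the source reports. "The series", "measured", "known", "first", "only" and "open" are said of these compounds alone.

Compound 2 `CC(=O)OC[C@H]1O[C@@H](n2cc3c(C#Cc4ccc(C)cc4)c(-c4ccc(C)cc4)oc3nc2=O)C[C@@H]1OC(C)=O` stands highest of the two numbers in an ADME assay on HEL cells (Homo sapiens) for cytotoxicity, read by cell counting, with a stated time of 3 days (a higher number here means that more compound is tolerated, a lower number that less compound is tolerated), where compound 2 gives 60000 nM. Within the data shown here, its only measured neighbour is compound 1 `CCCCCc1ccc(C#Cc2c(-c3ccc(C)cc3)oc3nc(=O)n([C@H]4C[C@H](OC(C)=O)[C@@H](COC(C)=O)O4)cc23)cc1`, which in this assay gives 20000 nM; the step of a 3.0-fold higher number from compound 1 to compound 2 (0.48 log units; beyond the scatter) is the single piece of evidence and describes a change at the outer end of the same triple-bonded substituent. Compound 3 `CC(=O)OC[C@H]1O[C@@H](n2cc3c(C#CCCO)c(-c4ccc(C)cc4)oc3nc2=O)C[C@@H]1OC(C)=O` differs from compound 2 by 2-hydroxyethyl in place of 4-methylphenyl on a triple-bonded carbon. Among the measured compounds shown here, that step in the evidence pointed to a higher number when the group at that end was cut back; no measured pair covers a change as large as this one. He therefore expects for compound 3 at most a small step in this assay, if any, in the direction of a higher number, and estimates a 1.3-fold higher number from compound 2 to compound 3 (0.12 log units; within the scatter) rather than anything beyond the scatter. His estimate for compound 3 in this assay is 80000 nM, in the range 30000 nM to 200000 nM.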

Compound 3, minimum cytotoxic concentration: > 100000 nM
Compound 3: no number, only a limit; the forecaster's own chance of this, stated with the estimate: 30%; middle value at least 1.2-fold (0.09 log units) away from the limit.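

In this assay compound 3 gives > 100000 nM as a limit of the assay and not as a number. On the triple-bonded carbon, 2-hydroxyethyl in place of 4-methylphenyl gives an at least 1.6-fold higher number from compound 2 to compound 3 (0.22 log units; that floor lies within the scatter) and so, on that floor alone, shows no separation beyond the scatter. With 2-hydroxyethyl in place of 4-pentylphenyl the step is an at least 5.0-fold higher number from compound 1 to compound 3 (0.69 log units; beyond the scatter) and shows what the earlier pair could not, that the six-membered aromatic ring can leave this carbon with no fall in the number, though the true size of the rise stays hidden: the limit of > 100000 nM in this assay, at which 1 of the 3 values shown sits.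

The compounds shown leave open whether the hydroxyl or the loss of the ring carries this step. A plain alkyl chain, a longer chain ending in hydroxyl or an amine at that end would help to separate the two.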